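This account rests on a few compounds, and the source may have more. Where it says the series, first, only, none or still open, it means among the compounds named here.

In a functional assay on ZR-75-1 cells (Homo sapiens) for cytotoxicity, read by MTT assay, with a stated time of 68 h (on this read-out higher numbers stand for weaker inhibition and lower numbers for stronger inhibition), compound 3 `O=C(/C=C/c1cccc(OCc2ccccc2)c1)c1ccccc1Br` gives 2900 nM and so sits within the scatter of compound 1 `O=C(/C=C/c1cccc(OCc2ccccc2)c1)c1ccc(O)cc1` at 4900 nM and clearly under compound 2 `Cc1ccc(C(=O)/C=C/c2cccc(OCc3ccccc3)c2)cc1` at 25800 nM on this scale. Compound 4 `O=C(/C=C/c1cccc(OCc2ccccc2)c1)c1cccc(Br)c1` has 3-bromophenyl in place of 2-bromophenyl on a carbonyl carbon, so the same atoms are joined differently. Among the measured compounds shown here, no measured pair shows this exact swap, so the closest evidence is two changes at that same place, where an 8.9-fold lower number from compound 2 to compound 3 (0.95 log units; beyond the scatter) lies beyond the scatter and a 1.7-fold lower number from compound 1 to compound 3 (0.23 log units; within the scatter) stays within it. Here a bromophenyl stays on that carbon, so no step beyond the scatter is expected. The estimated step is a 1.2-fold higher number from compound 3 to compound 4 (0.08 log units; within the scatter) and has no firm direction. In this assay compound 4 is estimated at 3500 nM with a likely range from 1200 nM to 11000 nM around that figure.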

Compound 4, half-maximal inhibitory concentration: 8300 nM
Compound 4: the middle estimate sits 2.4-fold (0.38 log units) below what was measured, within the range that was stated.
By their numbers in this assay, from the lowest: compounds 3, 1 and 4 (each within the scatter of the next, the first and the last beyond it); then compound 2.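

Where the bromine sits on this ring matters in this assay, even with the same atoms on the carbonyl carbon: the swap from 2-bromophenyl to 3-bromophenyl gives a real change (a 2.9-fold higher number from compound 3 to compound 4 (0.46 log units; beyond the scatter)). Compared with 4-methylphenyl, the 3-bromophenyl group still gives stronger inhibition (a 3.1-fold lower number from compound 2 to compound 4 (0.49 log units; beyond the scatter)), while compared with 4-hydroxyphenyl it stays within the scatter (a 1.7-fold higher number from compound 1 to compound 4 (0.23 log units; within the scatter)). Nothing available explains the gap between the two bromophenyl groups.

Still open, as far as these compounds go, is how 4-bromophenyl would compare with these two bromophenyl groups. From the compounds shown here alone, it is also open whether 2-chlorophenyl would track compound 3.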